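The source may hold more compounds than are shown below. What is called first, only, known or untested is meant among the compounds shown, and "the series" means these compounds.

Compound 1 `N#Cc1ccc(-c2cnc3[nH]cc(-c4nnc(-c5ccc(F)cc5)o4)c(=O)c3c2)cc1`: 18.9%
Compound 2 `CS(=O)(=O)c1ccc(-c2cnc3[nH]cc(-c4nnc(-c5ccccc5)o4)c(=O)c3c2)cc1`: 15.7%
Compound 3 `O=c1c(-c2nnc(-c3ccc(F)cc3)o2)c[nH]c2ncc(-c3cccnc3)cc12`: 19.7%

In a functional assay on HCT-116 cells (Homo sapiens) for inhibition, read by MTT assay, with a stated time of 24 h, tested at 10 uM (on this read-out higher numbers stand for more inhibition of growth at the one concentration tested and lower numbers for less inhibition of growth), the three measured compounds share one core and all give modest numbers. Compound 2 gives 15.7%, which comes out lowest of the three, with compound 1 nearest and compound 3 furthest, both gaps within the scatter. For the measured compounds named here, the only one-place step measured, a number 0.8 percentage points higher from compound 1 to compound 3 (within the scatter), also stays within the scatter. Compound 4 `Cc1ccc(-c2nnc(-c3c[nH]c4ncc(-c5ccc(S(C)(=O)=O)cc5)cc4c3=O)o2)cc1` differs from compound 2 by methyl in place of hydrogen on an aromatic carbon. Going by the values given here, no measured step touches that ring, and the one measured step changed nothing beyond the scatter, so no change beyond the scatter is expected here either. Compound 4 is therefore estimated at 16%, within a range of 6% to 28%. The expected step is a number 0.3 percentage points higher from compound 2 to compound 4 (within the scatter).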

Compound 4, percent growth inhibition at one concentration: 24.4%
The estimate for compound 4 lay 8.4 percentage points below the measured number; the measured number falls inside the stated range.
By their numbers in this assay, from the lowest: compounds 2, 1, 3 and 4 (each within the scatter of the next).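

For the compounds shown here, putting methyl on the phenyl group of compound 2, para to a large group, gives the first measured step at this ring, a number 8.7 percentage points higher from compound 2 to compound 4 (within the scatter) in this assay. Phenyl to 4-methylphenyl therefore shifts the number by no more than the scatter of this read-out, so this carbon accepts a methyl without a clear change. Nothing available explains the size of this step. Going by these compounds, whether an amine, a carboxylic acid or a longer chain on this carbon would move the number beyond the scatter remains open. So does whether methyl would behave the same with pyridin-3-yl elsewhere on the core.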